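From an inactive butyl compound to a vinyl one

The compounds below may be only part of what the source reports. "The series", "measured", "known", "first", "only" and "open" are said of these compounds alone.

Of the compounds shown here, three that share one core have been tested so far in a functional assay on HL-60 cells (Homo sapiens) for antiproliferative activity, read by MTT assay; on this read-out higher numbers stand for weaker inhibition and lower numbers for stronger inhibition. Compound 1 (`O[C@@H]1[C@@H](OCc2ccccc2)[C@H](OCc2ccccc2)[C@@H](COCc2ccccc2)O[C@@H]1CC1CCCCC1`) gives 17200 nM and compound 2 (`C=C[C@@H]1O[C@H](COCc2ccccc2)[C@@H](OCc2ccccc2)[C@H](OCc2ccccc2)[C@H]1O`) gives 11800 nM. These two values lie within the usual scatter of each other, and both are modest for this kind of test, where a lower number means stronger inhibition. Compound 3 (`CCCC[C@H]1O[C@H](COCc2ccccc2)[C@@H](OCc2ccccc2)[C@H](OCc2ccccc2)[C@H]1O`) stands apart, reported only as "not active" (no number reported). It therefore has no number that could be placed beside the other two.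

The next compound to be tested, compound 4 (`C=C[C@H]1O[C@H](COCc2ccccc2)[C@@H](OCc2ccccc2)[C@H](OCc2ccccc2)[C@H]1O`), changes one group of compound 3: vinyl in place of butyl on a saturated ring carbon. In words, vinyl takes the place of butyl on a saturated ring carbon, next to the ring oxygen.

With no number for compound 3, the size of this step cannot be stated exactly. Its expected direction in this assay is toward stronger inhibition, from no number to a measurable but still weak value. Compound 2 also bears a vinyl group at that place. Compound 2 gives 11800 nM. This rests on a single compound, so another result without a number remains possible. The expected value for compound 4 is 15000 nM, with an estimated range of 6000 nM to 40000 nM.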

Compound 4, half-maximal inhibitory concentration: "not active" (no number reported)
Nothing numeric was reported for compound 4, so the estimate cannot be set against anything.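

Going by these compounds alone, compound 4, like compound 3, is reported as not active in this assay with no number, so no step between the two can be read. Compound 2 gives 11800 nM and compound 4 gives no number, which leaves open whether activity in this pair turns on the one difference between them: the fact that compounds 2 and 4 differ only in the configuration as drawn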